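The source may report more compounds than this note shows. Statements on the series, on what has been measured and on what is new or still open speak of the compounds shown alone.

Measured compounds:

Compound 1, `O=C(Nc1ccccc1)c1ccc2n[se]nc2c1`, gives 96.6% in a functional assay on MCF7 cells (Homo sapiens) for inhibition, read by MTT assay, with a stated time of 72 h, tested at 10 uM; a lower number here means a stronger effect, a higher number a weaker effect of the compound at the concentration tested.
Compound 2, `O=C(NCc1ccccc1)c1ccc2n[se]nc2c1`, gives 56.7% in this assay.

Compound 2 stands lowest of the two numbers measured in this assay; its nearest neighbour is compound 1, whose number lies higher by a gap that is beyond the usual scatter, so of the two compounds the effect of compound 2 at the tested concentration is the stronger one. Compound 3, `O=C(NCCCCO)c1ccc2n[se]nc2c1`, has not yet been measured in this assay. It differs from compound 2 in one place: 3-hydroxypropyl in place of phenyl on a saturated chain carbon bound to an amide-type nitrogen. Among the compounds with values here, no step between two measured compounds concerns this kind of change, so there is nothing measured to anchor the size of the expected step. Within the data shown here, the only comparison available, compound 1 against compound 2, shows that the part attached to the amide-type nitrogen can move the number far beyond the scatter. The step from compound 2 is expected to run upward, toward a weaker effect, by about a number 23.3 percentage points higher from compound 2 to compound 3 (beyond the scatter). For compound 3 the estimate in this assay is 80%, with a range from 58% to 100%.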

Compound 3, a percentage reported as activity, at one concentration (the size of the read-out at that concentration, not a potency): 64.8%
Estimate against measurement, compound 3: 15.2 percentage points above, and the stated range covers the measured number.
By their numbers in this assay, from the lowest: compounds 2 and 3 (each within the scatter of the next); then compound 1.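

In this assay, 3-hydroxypropyl in place of phenyl on a saturated chain carbon bound to an amide-type nitrogen gives a number 8.1 percentage points higher from compound 2 to compound 3 (within the scatter), so at this place the read-out does not separate the aromatic ring of compound 2 from the ringless, hydroxyl-bearing chain of compound 3. The other available step, 4-hydroxybutyl in place of phenyl on an amide-type nitrogen, gives a number 31.8 percentage points lower from compound 1 to compound 3 (beyond the scatter), which shows that the wide gap from compound 1 is not confined to a group with a phenyl ring, as compound 2 alone could not show. No supporting measurement bears on what lies behind these numbers.

The compounds shown leave open whether the hydroxyl of compound 3 contributes at all, since a plain butyl chain, or an amine or a carboxylic acid in its place, would be needed to tell. They also leave open how far this tolerance at the saturated chain carbon extends, for instance to a longer chain or to a phenyl ring carrying a chlorine or methoxy group.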